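Chloromethyl to iodomethyl on two related pyrazole sugar cores

The source may report more compounds than this note shows. Statements on the series, on what has been measured and on what is new or still open speak of the compounds shown alone.

Compound 1 `CC(=O)OC[C@@H]1OC(n2nc(CCl)cc2C(N)=O)[C@@H](OC(C)=O)[C@H](OC(C)=O)[C@H]1OC(C)=O` gives 18 ug/mL in a functional assay on HeLa cells (Homo sapiens); on this read-out higher numbers stand for an effect only at larger amounts of compound and lower numbers for an effect already at smaller amounts. Compound 2 `CC(=O)OC[C@@H]1OC(n2nc(CI)cc2C(N)=O)[C@@H](OC(C)=O)[C@H](OC(C)=O)[C@H]1OC(C)=O` carries iodo in place of chloro on a saturated chain carbon bound to an aromatic carbon and gives 2 ug/mL, a step of a 9.0-fold lower number from compound 1 to compound 2 (0.95 log units; beyond the scatter). Compound 3 `CC(=O)OC[C@H]1O[C@@H](n2nc(C(N)=O)cc2CCl)[C@H](OC(C)=O)[C@@H]1OC(C)=O` rests on a different core; the difference between the two cores is not broken down here. In this assay compound 3 gives 12 ug/mL. Compound 4 `CC(=O)OC[C@H]1O[C@@H](n2nc(C(N)=O)cc2CI)[C@H](OC(C)=O)[C@@H]1OC(C)=O` differs from compound 3 by iodo in place of chloro on a saturated chain carbon bound to an aromatic carbon, the same change as before, at the same kind of place. Because a 9.0-fold lower number from compound 1 to compound 2 (0.95 log units; beyond the scatter) was a clear step beyond the usual scatter, a step of similar size is expected here, with some caution since it rests on a single pair. The expected step of a 6.7-fold lower number from compound 3 to compound 4 (0.82 log units; beyond the scatter) is estimated accordingly. Compound 4 is therefore expected to give about 1.8 ug/mL, most likely between 0.6 ug/mL and 6 ug/mL.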

Compound 4, concentration for half-maximal effect: 2 ug/mL
Compound 4: middle estimate off by 1.1-fold (0.05 log units), on the low side; the range from low to high includes it.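

In this assay, iodo in place of chloro again gives a clear step, a 6.0-fold lower number from compound 3 to compound 4 (0.78 log units; beyond the scatter). Among the compounds shown here, this supports carrying the change from one core to the other, but it rests on only two pairs of compounds, so it sets no rule for other cores and does not explain why the number falls. The two steps are of much the same size: the same change on two cores in this assay, a 9.0-fold lower number (0.95 log units; beyond the scatter) from compound 1 to compound 2 and a 6.0-fold lower number (0.78 log units; beyond the scatter) from compound 3 to compound 4, 1.5-fold (0.18 log units) apart, within the scatter of two such steps

The compounds shown leave open how a bromo group, an amine or a carboxylic acid would read on a saturated chain carbon bound to an aromatic carbon. They also leave open whether a longer chain carrying the iodo group would give a similar number in this assay.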